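From amino to methylamino at the assay limit

This account rests on a few compounds, and the source may have more. Where it says the series, first, only, none or still open, it means among the compounds named here.

In a functional assay on SKW3 cells (Homo sapiens) for antiproliferative activity, read by WST assay, with a stated time of 3 days (on this read-out higher numbers stand for weaker inhibition and lower numbers for stronger inhibition), compound 1 `O=c1cc(I)n([C@@H]2O[C@H](CO)[C@@H](O)[C@H]2O)c(=O)[nH]1` gives 18900 nM. Compound 2 `Nc1cc(=O)[nH]c(=O)n1[C@@H]1O[C@H](CO)[C@@H](O)[C@H]1O` reads > 50000 nM, which is a limit of the assay and not a number. Its standing is therefore known only as the limit of > 50000 nM in this assay, at which 1 of the 2 values shown sits. Compound 3 `CNc1cc(=O)[nH]c(=O)n1[C@@H]1O[C@H](CO)[C@@H](O)[C@H]1O` differs from it in one place: methyl in place of hydrogen on a nitrogen on an aromatic ring, or amino to methylamino. Among the compounds with values here, only one measured step bears on this, and only indirectly: an at least 2.6-fold higher number from compound 1 to compound 2 (0.42 log units; beyond the scatter), where amino took the place of iodo, a change beyond the scatter towards weaker inhibition. Within the data shown here, that step does not test a methyl on the nitrogen, and no measured compound points to a gain from one. The expectation is thus that compound 3 stays close to the limit, with no change beyond the scatter. The estimated step is a number no higher from compound 2 to compound 3 (the limit leaves the size open). Compound 3 is estimated at 50000 nM, with an expected range from 20000 nM to 100000 nM.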

Compound 3, half-maximal inhibitory concentration: > 50000 nM
Compound 3 ended at the assay's limit; the forecaster's own chance of this, stated with the estimate: 75%; the middle value sits exactly at the limit.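

In this assay compound 3 reads > 50000 nM, which is a limit of the assay and not a number. Methylamino in place of iodo on an aromatic carbon gives an at least 2.6-fold higher number from compound 1 to compound 3 (0.42 log units; beyond the scatter), so this change, like amino in place of iodo before it, goes towards weaker inhibition, and the methyl on the nitrogen does not bring a readable value back. The step between the amino and the methylamino compound cannot be read, since both of its ends are limits, and so the iodo compound alone keeps a measured number in this short series: the limit of > 50000 nM in this assay, at which 2 of the 3 values shown sit.

On these data alone, how far compound 2 and compound 3 lie past that limit stays open, and with it whether the methyl on the nitrogen has any effect on inhibition at all. Also open, as far as these compounds go, is whether a bromo or chloro group on that aromatic carbon, or a larger nitrogen substituent such as dimethylamino or ethylamino, would give a number that can be compared with compound 1.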